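From furan-3-yl to oxolan-3-yl on the carbonyl

The compounds below may be only part of what the source reports. "The series", "measured", "known", "first", "only" and "open" are said of these compounds alone.

Of the compounds shown here, three built on a shared urea core have been measured in a physicochemical assay for lipophilicity, read by HPLC, with a stated time of 90 min, tested at 100 uM; a lower number here means a more polar compound, a higher number a more lipophilic compound. Compound 1 `O=C(Nc1ccc(OC(F)(F)F)cc1)NC1CCN(C(=O)c2ccoc2)CC1` gives 3.63, the second highest of the three numbers. For the measured compounds named here, compound 2 `O=C(Nc1ccc(C(F)(F)F)cc1)NC1CCN(C(=O)c2ccoc2)CC1` gives 3.5, and the only single-point step among the measured compounds, a number 0.13 log units lower from compound 1 to compound 2 (within the scatter), lies within the scatter. Going by the values given here, compound 3 `CCC(=O)N1CCC(NC(=O)Nc2ccc(C(F)(F)F)c(F)c2)CC1` gives 3.76, which is also within the scatter of compound 1; no single-point step connects these two.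

Compound 4 `O=C(Nc1ccc(OC(F)(F)F)cc1)NC1CCN(C(=O)C2CCOC2)CC1` has not yet been measured. Its difference from compound 1 is oxolan-3-yl in place of furan-3-yl on a carbonyl carbon, sitting on a carbonyl carbon whose other neighbour is an amide-type nitrogen in a ring. Among the compounds with values here, none of the measured steps touches this part of the molecule: the one step known, a number 0.13 log units lower from compound 1 to compound 2 (within the scatter), concerns the group on the aromatic ring and was itself within the scatter. Within the data shown here, the expectation therefore rests on the structural change alone, with no measured precedent in this set.

Compound 4 is expected to give about 3.3 in this assay, with a likely range from 2.9 to 3.7. This corresponds to an estimated step of a number 0.33 log units lower from compound 1 to compound 4 (beyond the scatter), a modest move downward that may or may not clear the scatter once measured.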

Compound 4, partition coefficient: 3.22
Estimate against measurement, compound 4: 0.08 log units above; the measured number falls inside the stated range.
By their numbers in this assay, from the lowest: compounds 4, 2, 1 and 3 (each within the scatter of the next, the first and the last beyond it).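

Up to this point, the only step read in this assay concerned the group on the aromatic ring and stayed within the scatter, so the carbonyl substituent had no measured precedent. Placing oxolan-3-yl in place of furan-3-yl on the carbonyl carbon gives a number 0.41 log units lower from compound 1 to compound 4 (beyond the scatter) and is the first single-point step in the set to clear the scatter, which shows that this position registers in the read-out even when the heavy-atom count, the hetero atom and the hydrogen-bond counts stay as they were, and the one five-membered aromatic ring gives way to one five-membered non-aromatic ring. Nothing available accounts for the size or direction of this step, so its origin stays unassigned.

The compounds shown leave open whether the same change gives a step of similar size with trifluoromethyl in place of trifluoromethoxy on the aromatic carbon, since this single pair is all there is at the carbonyl. Also open, from the compounds shown here alone, is how this position would read with an amine or a carboxylic acid on the oxolan-3-yl ring, or with a longer chain in its place.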